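Acyl variation on the shared diazabicyclic core

The compounds below may be only part of what the source reports. "The series", "measured", "known", "first", "only" and "open" are said of these compounds alone.

Within the data shown here, three amides of the shared core have numbers so far. Compound 1 `CC(C)C(=O)N1CC2CC(C1)N2` gives 20000 nM in an assay on SH-EP1 cells for agonist activity at Neuronal acetylcholine receptor; alpha4/beta2 (Homo sapiens), read by FLIPR and calcium flux; a higher number here means that more compound is needed for the effect, a lower number that less compound is needed. Compound 2 `O=C(C1CC=CC1)N1CC2CC(C1)N2` gives 17000 nM in this assay, and compound 3 `O=C(CC1C=CCC1)N1CC2CC(C1)N2` gives 37000 nM. Compound 1 thus stands with compound 2 and compound 3 inside one band; the three values lie within the scatter of one another, so no order among them can be read. Compound 4 `O=C([C@@H]1C[C@H]1F)N1CC2CC(C1)N2` is not yet measured. It differs from compound 1 by 2-fluorocyclopropyl in place of isopropyl on a carbonyl carbon, a 2-fluorocyclopropyl in place of isopropyl on a carbonyl carbon. Among the measured compounds shown here, no step between two measured compounds covers this kind of change, so the expected step of a 1.3-fold lower number from compound 1 to compound 4 (0.12 log units; within the scatter) is small, likely nothing beyond the scatter. For compound 4 the estimate in this assay is 15000 nM, within 5000 nM to 45000 nM.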

Compound 4, half-maximal effective concentration: 870 nM
Beside the measured number, compound 4's estimate is 17-fold (1.24 log units) above it; measured number outside the range, below it.
By their numbers in this assay, from the lowest: compound 4; then compounds 2, 1 and 3 (each within the scatter of the next, the first and the last beyond it).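

In this assay the group on the carbonyl carbon can clearly shift the number: 2-fluorocyclopropyl in place of isopropyl gives a 23-fold lower number from compound 1 to compound 4 (1.36 log units; beyond the scatter). Among these compounds, the three earlier amides sat in a single band and gave no sign of a step of this size at this position. Nothing in hand bears on the reason for the step. Open, going by these compounds, is whether the step needs the fluorine, which a plain cyclopropyl amide would test. Also open, on these data alone, is whether it depends on the two defined stereocentres, which the mirror-image 2-fluorocyclopropyl amide would test.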